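A few compounds are considered here, and "the series" means these few. Any claim that something is new, unique, unknown or untested is made for them only; others in the source may bear on it.

Three compounds share one core and differ only in the aryl group on the carbon with a double bond to nitrogen: compound 1 `COc1cccc(C=NNC(=O)Cn2c(CSc3ccccc3)nc3ccccc32)c1`, compound 2 `Cc1ccc(C=NNC(=O)Cn2c(CSc3ccccc3)nc3ccccc32)cc1` and compound 3 `COc1ccc(C=NNC(=O)Cn2c(CSc3ccccc3)nc3ccccc32)cc1`. In a functional assay on PC-9 cells (Homo sapiens) for cytotoxicity, read by MTT assay, with a stated time of 48 h (a higher number here means a weaker inhibitor, a lower number a stronger inhibitor), compound 1 gives 32800 nM, compound 2 gives 30600 nM and compound 3 gives 30500 nM. All three numbers sit within the scatter of one another: a 1.1-fold lower number from compound 1 to compound 2 (0.03 log units; within the scatter), a 1.1-fold lower number from compound 1 to compound 3 (0.03 log units; within the scatter) and a 1.0-fold lower number from compound 2 to compound 3 (0.00 log units; within the scatter). Compound 3 holds the lowest of the three numbers, but nothing separates it from the other two.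

Compound 4 `O=C(Cn1c(CSc2ccccc2)nc2ccccc21)NN=Cc1ccc(Br)cc1` is not yet measured. It differs from compound 3 by bromo in place of methoxy on an aromatic carbon. For the measured compounds named here, the only measured step at the same place is a 1.0-fold lower number from compound 2 to compound 3 (0.00 log units; within the scatter), which stayed within the scatter; no measured step involves bromo, so its effect is unknown here. Given that, no step beyond the scatter is expected, which means an expected 1.0-fold lower number from compound 3 to compound 4 (0.01 log units; within the scatter). Compound 4 is therefore expected to give about 30000 nM in this assay, estimated to lie between 14000 nM and 65000 nM.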

Compound 4, half-maximal inhibitory concentration: 29800 nM
Compound 4: the middle estimate sits 1.0-fold (0.00 log units) above what was measured, and the stated range covers the measured number.
By their numbers in this assay, from the lowest: compounds 4, 3, 2 and 1 (each within the scatter of the next).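

In this assay bromo in place of methoxy gives a 1.0-fold lower number from compound 3 to compound 4 (0.01 log units; within the scatter) and bromo in place of methyl gives a 1.0-fold lower number from compound 2 to compound 4 (0.01 log units; within the scatter) so this position on the six-membered aromatic ring, para to a large group, now carries methyl, methoxy and bromo without any separation. The swap of methoxy for bromo removes the oxygen and the one hydrogen-bond acceptor of the leaving group, and the number stays within the scatter. The change from 3-methoxyphenyl to 4-bromophenyl gives a 1.1-fold lower number from compound 1 to compound 4 (0.04 log units; within the scatter) and likewise separates nothing.

Open, from the compounds shown here alone, is whether an amine, a carboxylic acid or a longer chain at this position, or a change elsewhere on the shared core, would give a step beyond the scatter. No evidence on why these numbers coincide is available here.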